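Swapping a fluoro for hydrogen on the sulfonyl aryl

The source may hold more compounds than are shown below. What is called first, only, known or untested is meant among the compounds shown, and "the series" means these compounds.

Measured so far:
- compound 1, `CC(O)(CS(=O)(=O)c1ccc(F)cc1)c1cn(-c2ccc([N+](=O)[O-])c(C(F)(F)F)c2)nn1`, gives > 300000 nM in a functional assay on PC-3 cells (Homo sapiens) for inhibition; on this read-out lower numbers stand for stronger inhibition and higher numbers for weaker inhibition; this value is a limit of the assay, not a number.
- compound 2, `CCOC(=O)c1ccc(-n2cc(C(C)(O)CS(=O)(=O)c3ccc(F)cc3)nn2)cc1`, gives > 300000 nM in this assay; this value too is a limit of the assay.

Both compounds share the same core and differ only in the group attached to the triazole nitrogen. Compound 1 stands at the limit of the assay, and so does the other value shown: the limit of > 300000 nM in this assay, at which 2 of the 2 values shown sit. For the measured compounds named here, with only limits in hand, no step between measured compounds can be sized, and nothing separates compound 1 from compound 2 beyond the fact that both sit at the same limit.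

Compound 3, `CC(O)(CS(=O)(=O)c1ccccc1)c1cn(-c2ccc([N+](=O)[O-])c(C(F)(F)F)c2)nn1`, has not yet been measured. It differs from compound 1 in one place: hydrogen in place of fluoro on an aromatic carbon, so the (4-fluorophenyl)sulfonyl group becomes a phenylsulfonyl group while the rest of the molecule stays the same. Since compound 1 is already at the limit, there is no numeric starting point to move from, and the expectation for compound 3 is no step beyond the scatter, with a number no higher from compound 1 to compound 3 (the limit leaves the size open) reflecting that the same limit is expected to be reported. The estimate for compound 3 in this assay is 300000 nM, within the range 60000 nM to 300000 nM.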

Compound 3, half-maximal inhibitory concentration: 29000 nM
Beside the measured number, compound 3's estimate is 10-fold (1.01 log units) above it; the whole stated range lies above it.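

In this assay, hydrogen in place of fluoro on an aromatic carbon of the sulfonyl ring gives an at least 10-fold lower number from compound 1 to compound 3 (1.01 log units; beyond the scatter), which shows that the read-out at this position responds to a change of a single atom. Going by these compounds, compound 1 gives > 300000 nM, which is a limit of the assay and not a number, so the true size of the step stays open and only its lower bound is known. Compound 3 is the only compound shown with an actual number, giving a first measured point from which later changes in this series can be sized, while the other values remain at the limit: the limit of > 300000 nM in this assay, at which 2 of the 3 values shown sit.

The compounds shown leave open whether a chloro, a methoxy or an amine on that same aromatic carbon would give a still lower number or return to the limit. They also leave open whether hydrogen in place of fluoro would produce a similar step in compound 2, which carries a different group on the triazole nitrogen.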